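Compound 1 to compound 4 near the assay limit

The compounds below may be only part of what the source reports. "The series", "measured", "known", "first", "only" and "open" are said of these compounds alone.

In a functional assay on NCI-H1299 cells (Homo sapiens), read by flow cytometry (on this read-out higher numbers stand for an effect only at larger amounts of compound and lower numbers for an effect already at smaller amounts), compound 1 (`N#Cc1ncc2nc1OCC/C=C\COc1ccccc1NC(=O)N2`) gives > 10000 nM, which is a limit of the assay and not a number. Compound 2 (`CCOc1ccc2c(c1)NC(=O)Nc1cnc(C#N)c(n1)OCCCCCO2`) gives > 10000 nM, also a limit. Compound 3 (`N#Cc1ncc2nc1OCCCCCOc1ccc(Br)cc1NC(=O)N2`) reads 10000 nM. Little can be read from the series because of the limit of > 10000 nM in this assay, at which 2 of the 3 values shown sit.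

Compound 4 (`N#Cc1ncc2nc1OCC/C=C\COc1ccc(CCCOC3CCCCO3)cc1NC(=O)N2`) differs from compound 1 as follows: 3-((oxan-2-yl)oxy)propyl in place of hydrogen on an aromatic carbon. A 3-((oxan-2-yl)oxy)propyl group thus replaces hydrogen on an aromatic carbon of the core.

Within the data shown here, the one measured step with a change on an aromatic carbon is a number no higher from compound 2 to compound 3 (the limit leaves the size open), a swap of ethoxy for bromo whose size cannot be read. It involves a different group, so it offers only weak guidance. No clear step is expected in this assay, and compound 4 is expected to stay close to the limit. The estimated change is a number no higher from compound 1 to compound 4 (the limit leaves the size open). Compound 4 is estimated at 10000 nM, with an expected range of 3000 nM to 30000 nM.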

Compound 4, half-maximal effective concentration: > 10000 nM
Compound 4 gave a limit, no number; the forecaster's own chance of this, stated with the estimate: 60%; the middle value sits exactly at the limit.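

In this assay compound 4 gives > 10000 nM as a limit of the assay, not a number. Compound 1 gives > 10000 nM as a limit too. Among these compounds, no step between compound 1 and compound 4 can be read, because both sit at that limit: the limit of > 10000 nM in this assay, at which 3 of the 4 values shown sit.

From the compounds shown here alone, whether 3-((oxan-2-yl)oxy)propyl in place of hydrogen changes the read-out at all stays open.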